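The compounds below may be only part of what the source reports. "The series", "measured", "known", "first", "only" and "open" are said of these compounds alone.

In an ADME assay on cells (Hepatocyte, Mus musculus) for cytotoxicity, read by MTT assay, with a stated time of 24 h (on this read-out higher numbers stand for lower toxicity in this test and lower numbers for higher toxicity in this test), compound 1 `O=S(=O)(c1ccccc1)n1c(-c2cn(-c3ccccc3)nc2-c2ccc(F)cc2)nc2ccccc21` gives 231000 nM, compound 2 `COc1ccc(S(=O)(=O)n2c(-c3cn(-c4ccccc4)nc3-c3ccc(F)cc3)nc3ccccc32)cc1` gives 105000 nM, and compound 3 `Cc1ccc(C)c(S(=O)(=O)n2c(-c3cn(-c4ccccc4)nc3-c3ccc(F)cc3)nc3ccccc32)c1` gives 122000 nM. Compound 3 therefore lies within the scatter of both other compounds. The move to compound 4 `O=[N+]([O-])c1ccc(S(=O)(=O)n2c(-c3cn(-c4ccccc4)nc3-c3ccc(F)cc3)nc3ccccc32)cc1` is 4-nitrophenyl in place of 2,5-dimethylphenyl on a sulfonyl sulfur, placing 4-nitrophenyl on the sulfonyl sulfur in place of 2,5-dimethylphenyl. Three measured steps change the same aryl group: a 2.2-fold lower number from compound 1 to compound 2 (0.34 log units; beyond the scatter), a 1.9-fold lower number from compound 1 to compound 3 (0.28 log units; within the scatter), and a 1.2-fold higher number from compound 2 to compound 3 (0.07 log units; within the scatter). Only the first exceeds the scatter, and it is modest. As far as these compounds go, none introduces 4-nitrophenyl, so the direction remains open. The expected change is a 1.1-fold higher number from compound 3 to compound 4 (0.03 log units; within the scatter), which stays within the scatter. Compound 4 is estimated at 130000 nM, with an expected range of 65000 nM to 260000 nM.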

Compound 4, half-maximal cytotoxic concentration: > 300000 nM
Compound 4 was reported as a limit; the forecaster's own chance of this, stated with the estimate: 3%; at least 2.3-fold (0.36 log units) between middle value and limit.
By their numbers in this assay, from the lowest: compounds 2, 3 and 1 (each within the scatter of the next, the first and the last beyond it). At a limit, above all of these: compound 4.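

Among the compounds shown here, on the sulfonyl sulfur, the aryl group now gives steps beyond the scatter toward lower toxicity in this test, an at least 2.4-fold higher number from compound 3 to compound 4 (0.39 log units; beyond the scatter) and an at least 2.8-fold higher number from compound 2 to compound 4 (0.45 log units; beyond the scatter), whereas the only earlier step beyond the scatter, a 2.2-fold lower number from compound 1 to compound 2 (0.34 log units; beyond the scatter), went the other way. The remaining step, an at least 1.2-fold higher number from compound 1 to compound 4 (0.11 log units; that floor lies within the scatter), cannot be read as a difference, so 4-nitrophenyl is not separated from phenyl. Compound 4 is reported only as a limit: the limit of > 300000 nM in this assay, at which 1 of the 4 values shown sits. As far as these compounds go, how far compound 4 lies past that limit stays open. Also open, from the compounds shown here alone, is whether an aminophenyl or carboxyphenyl group on the sulfonyl sulfur would read like 4-nitrophenyl or like 4-methoxyphenyl.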